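The source may hold more compounds than are shown below. What is called first, only, known or untested is meant among the compounds shown, and "the series" means these compounds.

Compound 1 `O=S(=O)(NCCNC(=S)Nc1cc(C(F)(F)F)cc(C(F)(F)F)c1)c1ccc(-c2ccccc2OCc2ccccc2)s1`, compound 2 `O=S(=O)(NCCNC(=S)Nc1cc(C(F)(F)F)cc(C(F)(F)F)c1)c1ccc(-c2ccccc2Oc2ccc(O)c(O)c2)s1` and compound 3 `O=C(NCCNS(=O)(=O)c1ccc(-c2ccccc2Oc2ccc(O)c(O)c2)s1)Nc1cc(C(F)(F)F)cc(C(F)(F)F)c1` were tested in an ADME assay on HEK-293T cells (Homo sapiens) for cytotoxicity, read by CCK-8 assay, with a stated time of 48 h; on this read-out lower numbers stand for stronger inhibition and higher numbers for weaker inhibition. Compound 1 gives 8500 nM, compound 2 gives 12300 nM, and compound 3 gives 17100 nM. Compound 1 and compound 2 differ by benzyl in place of 3,4-dihydroxyphenyl on an oxygen on an aromatic ring, a change that made a 1.4-fold lower number from compound 2 to compound 1 (0.16 log units; within the scatter). Compound 2 and compound 3 share the same outer groups but differ in their cores, and that difference between the two cores is not broken down here. Compound 4 `O=C(NCCNS(=O)(=O)c1ccc(-c2ccccc2OCc2ccccc2)s1)Nc1cc(C(F)(F)F)cc(C(F)(F)F)c1` has not yet been measured in this assay. Among the compounds with values here, it differs from compound 3 by benzyl in place of 3,4-dihydroxyphenyl on an oxygen on an aromatic ring, the same change as the one between compound 2 and compound 1. Because the earlier step from compound 2 to compound 1 was a 1.4-fold lower number from compound 2 to compound 1 (0.16 log units; within the scatter), the step from compound 3 to compound 4 is expected to be a 1.4-fold lower number from compound 3 to compound 4 (0.14 log units; within the scatter), a small change in the same direction. Compound 4 is therefore estimated to give about 12500 nM in this assay, most likely between 6000 nM and 26000 nM.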

Compound 4, half-maximal inhibitory concentration: > 20000 nM
Compound 4: a limit, no number (the forecaster's own chance of this, stated with the estimate: 10%); middle value at least 1.6-fold (0.20 log units) from the limit.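

In this assay compound 4 gives > 20000 nM as a limit of the assay, not a number. On these data alone, putting benzyl in place of 3,4-dihydroxyphenyl on this core is an at least 1.1-fold higher number from compound 3 to compound 4 (0.06 log units; that floor lies within the scatter) and only that floor is known, so the size of the step remains unknown. The comparison neither shows that the change carries over from one core to the other nor shows that it fails to: the same change on two cores in this assay, a 1.4-fold lower number (0.16 log units; within the scatter) from compound 2 to compound 1 and an at least 1.1-fold higher number (0.06 log units; that floor lies within the scatter) from compound 3 to compound 4; the limit leaves it open whether they differ.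

The compounds shown leave open how a methyl group or a longer alkyl chain on that oxygen would compare with benzyl and 3,4-dihydroxyphenyl. They also leave open how the same change would read on a third core.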